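One Chain Carbon Fewer in a Well-Tolerated Compound

The source may hold more compounds than are shown below. What is called first, only, known or untested is meant among the compounds shown, and "the series" means these compounds.

Compound 1 (`CCCC(=O)Nc1ncc(-c2ccc(OC)cc2)n1C`) reads > 100000 nM in a toxicity assay on THP-1 cells (Homo sapiens) for inhibition (a higher number here means that more compound is tolerated, a lower number that less compound is tolerated), and this is a limit of the assay, not a number. Going by the values given here, compound 2 (`Cn1c(-c2ccccc2Cl)cnc1NC(=O)c1ncc[nH]1`), the only other compound measured, reads > 50000 nM, and this too is a limit. Compound 1 therefore stands at a limit, with no exact value beside it for comparison. Compound 3 (`CCC(=O)Nc1ncc(-c2ccc(OC)cc2)n1C`) differs from compound 1 in one place: hydrogen in place of methyl on a saturated chain carbon, two bonds along the chain from a carbonyl carbon. Hydrogen takes the place of methyl on a saturated chain carbon, two bonds along the chain from a carbonyl carbon, so propyl becomes ethyl. Among the compounds with values here, no measured step is available to size this change, so no shift in either direction beyond the usual scatter is expected in this assay. The estimated step is a number no higher from compound 1 to compound 3 (the limit leaves the size open). Compound 3 is expected at 100000 nM, with an estimated range of 40000 nM to 200000 nM.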

Compound 3, half-maximal cytotoxic concentration: > 100000 nM
Compound 3: no number, only a limit; the forecaster's own chance of this, stated with the estimate: 85%; the middle value sits exactly at the limit.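

No new step can be read from compound 1 to compound 3 in this assay, since each compound reads only as a limit of the assay: the limit of > 100000 nM in this assay, at which 2 of the 3 values shown sit.

The compounds shown leave open how much of either compound is tolerated, and whether going from propyl to ethyl changes that at all.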